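Chloro to methoxy on the aromatic amide

The source may report more compounds than this note shows. Statements on the series, on what has been measured and on what is new or still open speak of the compounds shown alone.

compound 1 `CN(C)CCNc1cc2c(cn1)cc(NC(=O)/C=C/c1ccccc1)c(=O)n2C`: 27400 nM
compound 2 `CC(=O)Nc1cc2cnc(NCCN(C)C)cc2n(C)c1=O`: > 100000 nM, a limit of the assay and not a number
compound 3 `CN(C)CCNc1cc2c(cn1)cc(NC(=O)c1ccc(Cl)cc1)c(=O)n2C`: 3090 nM

Within the data shown here, in a functional assay on MCF7 cells (Homo sapiens) for antiproliferative activity, read by MTT assay, with a stated time of 48 h (on this read-out higher numbers stand for weaker inhibition and lower numbers for stronger inhibition), compound 3 gives 3090 nM, the lowest number so far. The nearest number belongs to compound 1 at 27400 nM. The next molecule, compound 4 `COc1ccc(C(=O)Nc2cc3cnc(NCCN(C)C)cc3n(C)c2=O)cc1`, differs from compound 3 in one place: methoxy in place of chloro on an aromatic carbon, para to a large group (methoxy in place of chloro on an aromatic carbon).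

Each measured step exchanges the whole group on the carbonyl carbon. Putting 4-chlorophenyl in place of methyl gave an at least 32-fold lower number from compound 2 to compound 3 (1.51 log units; beyond the scatter), and putting it in place of 2-phenylethenyl gave an 8.9-fold lower number from compound 1 to compound 3 (0.95 log units; beyond the scatter). Going from 2-phenylethenyl to methyl gave an at least 3.6-fold higher number from compound 1 to compound 2 (0.56 log units; beyond the scatter). Among the measured compounds shown here, no measured step swaps a group on the phenyl ring while keeping that ring, so these steps offer only a loose guide. Compound 4 keeps the ring, so a much smaller change than an at least 32-fold lower number from compound 2 to compound 3 (1.51 log units; beyond the scatter) is expected. With compound 3 already lowest at 3090 nM, a slight lean towards a higher number seems reasonable in this assay. The expected change is a 1.9-fold higher number from compound 3 to compound 4 (0.29 log units; within the scatter). For compound 4 the estimated value is 6000 nM, with an expected range from 2000 nM to 20000 nM.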

Compound 4, half-maximal inhibitory concentration: 37300 nM
Compound 4: middle estimate off by 6.2-fold (0.79 log units), on the low side; the whole stated range lies below it.
By their numbers in this assay, from the lowest: compound 3; then compounds 1 and 4 (each within the scatter of the next). At a limit, above all of these: compound 2.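

Swapping chloro for methoxy while the ring stays in place is a large change in this assay: a 12-fold higher number from compound 3 to compound 4 (1.08 log units; beyond the scatter), whereas every earlier step replaced the whole group on the carbonyl carbon, so a single substituent on this ring, para to a large group, had not been tested alone. The advantage of compound 3 over compound 1 therefore does not come with any phenyl ring on the amide, since the 4-methoxyphenyl group gives no clear difference from 2-phenylethenyl: a 1.4-fold higher number from compound 1 to compound 4 (0.13 log units; within the scatter). The 4-methoxyphenyl group still improves on methyl, with an at least 2.6-fold lower number from compound 2 to compound 4 (0.42 log units; beyond the scatter), and this step has only a one-sided size, as the entry for compound 2 is a limit of the assay and not a number: the limit of > 100000 nM in this assay, at which 1 of the 4 values shown sits.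

The compounds shown hold only chloro and methoxy at this place, so it stays open how fluoro, trifluoromethyl or an amine there would compare, and whether any group would give a lower number than chloro. These numbers alone cannot tell why the two groups differ so much, and they describe a single cell line.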